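Methoxy for Bromo on the Phenoxy Ring

A few compounds are considered here, and "the series" means these few. Any claim that something is new, unique, unknown or untested is made for them only; others in the source may bear on it.

Measured compounds:
compound 1, `Nc1nc(N2CCN(C(=O)COc3ccc(Cl)cc3)CC2)c2nc(-c3ccc(F)cc3)sc2n1`, 490 nM
compound 2, `Nc1nc(N2CCN(C(=O)COc3ccc(F)cc3)CC2)c2nc(-c3ccc(F)cc3)sc2n1`, 70 nM
compound 3, `Nc1nc(N2CCN(C(=O)COc3ccc(Br)cc3)CC2)c2nc(-c3ccc(F)cc3)sc2n1`, 380 nM

In a functional assay on cells (Lymphocyte, Homo sapiens) (a higher number here means a weaker inhibitor, a lower number a stronger inhibitor), compound 3 stands second highest of the three numbers. Its nearest neighbour is compound 1, with a 1.3-fold lower number from compound 1 to compound 3 (0.11 log units; within the scatter); its furthest is compound 2, with a 5.4-fold higher number from compound 2 to compound 3 (0.73 log units; beyond the scatter). Compound 4, `COc1ccc(OCC(=O)N2CCN(c3nc(N)nc4sc(-c5ccc(F)cc5)nc34)CC2)cc1`, differs from compound 3 in one place: methoxy in place of bromo on an aromatic carbon. For the measured compounds named here, the steps measured so far exchange one halogen for another at this position, and a 7.0-fold lower number from compound 1 to compound 2 (0.85 log units; beyond the scatter) together with a 5.4-fold higher number from compound 2 to compound 3 (0.73 log units; beyond the scatter) show that such a change can move the number modestly; no measured step introduces a methoxy group. Compound 4 is therefore expected to show a 1.9-fold lower number from compound 3 to compound 4 (0.28 log units; within the scatter), an estimate of 200 nM with a range from 50 nM to 800 nM.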

Compound 4, half-maximal inhibitory concentration: 40 nM
Beside the measured number, compound 4's estimate is 5.0-fold (0.70 log units) above it; measured number below the stated range.
By their numbers in this assay, from the lowest: compounds 4 and 2 (each within the scatter of the next); then compounds 3 and 1 (each within the scatter of the next).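

In this assay, the methoxy group falls on the low side of this position: a 9.5-fold lower number from compound 3 to compound 4 (0.98 log units; beyond the scatter) and a 12-fold lower number from compound 1 to compound 4 (1.09 log units; beyond the scatter) both lie beyond the scatter, whereas a 1.8-fold lower number from compound 2 to compound 4 (0.24 log units; within the scatter) lies within it. The step therefore joins compound 4 with compound 2 and apart from compound 1 and compound 3, and the heavy-atom count of the group does not order the numbers. Nothing measured here accounts for this division. From the compounds shown here alone, whether an ethoxy group or an amine at this position would stay with compound 2 and compound 4 remains open.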